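A few compounds are considered here, and "the series" means these few. Any claim that something is new, unique, unknown or untested is made for them only; others in the source may bear on it.

Of the compounds shown here, two built on a shared core have been measured in a functional assay on UO-31 cells (Homo sapiens) for inhibition, read by sulforhodamine B assay, with a stated time of 48 h, tested at 10 uM; a higher number here means more inhibition at the concentration tested (going by the name of the read-out), a lower number less inhibition. Compound 1 `Fc1ccc(-c2cn3ccnc3c(-c3ccc4ncn(C5CCCCC5)c4c3)n2)cc1` gives 37.8%. For the measured compounds named here, compound 2 `COc1ccccc1-c1cn2ccnc2c(-c2ccc3ncn(C4CCCCC4)c3c2)n1` gives 24%, the lower of the two numbers, and the one measured step, a number 13.8 percentage points lower from compound 1 to compound 2 (beyond the scatter), goes with 2-methoxyphenyl in place of 4-fluorophenyl on an aromatic carbon. Compound 3 `c1csc(-c2cn3ccnc3c(-c3ccc4ncn(C5CCCCC5)c4c3)n2)c1` has not been measured in this assay. It differs from compound 2 by thiophen-2-yl in place of 2-methoxyphenyl on an aromatic carbon. Going by the values given here, no measured step exchanges a six-membered aromatic ring for thiophen-2-yl, so the step from compound 1 to compound 2 bears on it only loosely: it shows that exchanging the group at this place can move the read-out by a modest amount beyond the scatter, in either direction as far as the data go. Compound 2 stands at the low end of the two numbers, with compound 1 at 37.8% above it, and a number between the two is expected. Compound 3 is expected to give 30%, within 15% to 45%. The step of a number 6 percentage points higher from compound 2 to compound 3 (within the scatter) is thus estimated to lie near the edge of the scatter.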

Compound 3, a percentage reported as inhibition, at one concentration (the size of the read-out at that concentration, not a potency): 10.9%
The estimate for compound 3 lay 19.1 percentage points above the measured number, and the stated range ends above it.
By their numbers in this assay, from the lowest: compound 3; then compound 2; then compound 1.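

In this assay, thiophen-2-yl on this aromatic carbon gives the lowest number of the three, with a number 13.1 percentage points lower from compound 2 to compound 3 (beyond the scatter) and a number 26.9 percentage points lower from compound 1 to compound 3 (beyond the scatter). The earlier pair showed only that exchanging one six-membered aromatic ring for another could move the read-out at this place; this result adds a different kind of ring, a five-membered aromatic ring with a sulfur atom, and its number falls below those of both compounds that carry a six-membered ring of carbon only. Across these three compounds, the read-out thus stays sensitive to the group at this place, and the change of ring size goes with the lowest number, though a single five-membered example cannot separate ring size from the presence of sulfur, and no measurement at hand accounts for the fall.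

The compounds shown leave open whether furan-2-yl, with oxygen in place of sulfur, would stand near thiophen-2-yl or nearer the two six-membered rings. They also leave open how a non-aromatic group at this place, such as a morpholine or a short alkyl chain, would compare with the aromatic rings.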